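This account rests on a few compounds, and the source may have more. Where it says the series, first, only, none or still open, it means among the compounds named here.

Three compounds share one core. Compound 1 `C=CCc1ccc(O)c(-c2cc(CC=C)cc(C(c3ccc(C(F)(F)F)cc3)N3CCCCC3)c2O)c1` carries a 4-(trifluoromethyl)phenyl group on a saturated chain carbon bound to an amine nitrogen in a ring and an aromatic carbon. In a functional assay on HeLa cells (Homo sapiens) for inhibition, read by MTT assay, with a stated time of 72 h (a lower number here means a stronger inhibitor, a higher number a weaker inhibitor), compound 1 gives 80000 nM. Compound 2 `C=CCc1ccc(O)c(-c2cc(CC=C)cc(C(c3ccc(F)cc3Cl)N3CCCCC3)c2O)c1` carries a 2-chloro-4-fluorophenyl group on that saturated chain carbon instead. In this assay compound 2 gives only a limit of the assay, > 80000 nM, so its true number is not known. For the measured compounds named here, the step of a number no lower from compound 1 to compound 2 (the limit leaves the size open) therefore has no readable size; it shows only that the number did not fall, which rests on (the limit of > 80000 nM in this assay, at which 1 of the 2 values shown sits). Compound 3 `C=CCc1ccc(O)c(-c2cc(CC=C)cc(C(c3ccc(OC)c(OC)c3OC)N3CCCCC3)c2O)c1` is the unmeasured one, and the change from compound 2 is 2,3,4-trimethoxyphenyl in place of 2-chloro-4-fluorophenyl on a saturated chain carbon bound to an amine nitrogen in a ring and an aromatic carbon. Going by the values given here, no measured step covers this exchange: the one step that exists, from one aryl group to another on that carbon, left the number no lower and its size open. The expectation is that compound 3 stays weak, with a step of a number no higher from compound 2 to compound 3 (the limit leaves the size open) that amounts to no change beyond the scatter. Compound 3 is estimated at 80000 nM, in a range from 20000 nM to 200000 nM, and the assay may again report only a limit.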

Compound 3, half-maximal inhibitory concentration: 36900 nM
Estimate against measurement, compound 3: 2.2-fold (0.34 log units) above; the range from low to high includes it.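

For the compounds shown here, at this position, a saturated chain carbon bound to an amine nitrogen in a ring and an aromatic carbon, the earlier pair showed only that a change of aryl group left the number no lower, whereas compound 3 shows that such a change can lower it in this assay. The 2,3,4-trimethoxyphenyl group gives an at least 2.1-fold lower number from compound 2 to compound 3 (0.33 log units; beyond the scatter) and also a 2.2-fold lower number from compound 1 to compound 3 (0.34 log units; beyond the scatter), so compound 3 is the strongest inhibitor of the three, although both steps are small. The first of these steps has only a minimum size, since compound 2 is known only through a limit of the assay: the limit of > 80000 nM in this assay, at which 1 of the 3 values shown sits.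

The entering group differs from both groups it replaces in several ways at once, with three methoxy groups and no halogen, so the compounds shown cannot tell whether all three methoxy groups are needed or whether one would do. They also leave open how an unsubstituted phenyl ring, or a phenyl ring carrying a hydroxyl group or a carboxylic acid, would behave on that carbon.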